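The compounds below may be only part of what the source reports. "The series", "measured", "known", "first", "only" and "open" are said of these compounds alone.

Of the compounds shown here, three have been measured in a functional assay on HT-29 cells (Homo sapiens) for cytotoxicity, read by MTT assay, with a stated time of 72 h (on this read-out lower numbers stand for higher toxicity in this test and higher numbers for lower toxicity in this test), and the numbers sit close together. Compound 1, `CCCOC(=O)Nc1ccc([Se]C#N)cc1`, gives 75400 nM in this assay. Compound 3, `CCCCCCOC(=O)Nc1ccc([Se][Se]c2ccc(NC(=O)OCCCCCC)cc2)cc1`, gives 74200 nM in this assay, and compound 2, `O=C(Nc1ccc([Se][Se]c2ccc(NC(=O)OCc3ccccc3)cc2)cc1)OCc1ccccc1`, gives 69000 nM in this assay. The gaps from compound 1 to compound 3 and to compound 2 both lie within the usual scatter, so the three values show no real separation; compound 1 stands alongside the other two rather than apart from them.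

The next compound, compound 4, `N#C[Se]c1ccc(NC(=O)OCc2ccccc2)cc1`, is not yet measured. It is made from compound 1 by one change: phenyl in place of ethyl on a saturated chain carbon bound to an oxygen next to a carbonyl group. In words, a phenyl stands in place of an ethyl on a saturated chain carbon bound to an oxygen next to a carbonyl group, so the carbamate carries a benzyl group instead of a propyl group. For the measured compounds named here, no pair of measured compounds reproduces this exact change, but compound 2 and compound 3, which differ in the same region of the carbamate, show values within the scatter of each other.

On that basis the step from compound 1 to compound 4 is expected to be small, a 1.0-fold lower number from compound 1 to compound 4 (0.02 log units; within the scatter), with no direction beyond the scatter. Compound 4 is therefore estimated to give about 72000 nM in this assay, with a likely range from 36000 nM to 144000 nM.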

Compound 4, concentration lethal to 50% of the cells: 69100 nM
Compound 4: the middle estimate sits 1.0-fold (0.02 log units) above what was measured; measured number inside the range.
By their numbers in this assay, from the lowest: compounds 2, 4, 3 and 1 (each within the scatter of the next).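

For the compounds shown here, this is the first pair here that differs in one place only, and it gives a direct reading of this position: with phenyl in place of ethyl on a saturated chain carbon bound to an oxygen next to a carbonyl group, a 1.1-fold lower number from compound 1 to compound 4 (0.04 log units; within the scatter) appears in this assay. Swapping the open chain for an aromatic ring therefore leaves the read-out within the scatter, at least for this single pair, so this position tolerates that change in this test. Nothing measured here explains why the change has so little effect.

From the compounds shown here alone, it remains open whether a group of another kind at this position, such as an amine or a carboxylic acid, would move the number beyond the scatter. One pair also cannot show whether the same swap would behave alike on a different core.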